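This account rests on a few compounds, and the source may have more. Where it says the series, first, only, none or still open, it means among the compounds named here.

In a functional assay on A549 cells (Homo sapiens) for cytotoxicity, read by MTT assay, with a stated time of 72 h (on this read-out higher numbers stand for weaker inhibition and lower numbers for stronger inhibition), compound 1 `COc1cc(Nc2nc3ccccc3nc2S(=O)(=O)c2ccccc2)cc(OC)c1` gives 70 nM, compound 2 `Cc1ccc(S(=O)(=O)c2nc3ccccc3nc2Nc2ccccc2)cc1` gives 12500 nM, and compound 3 `COc1cc(Nc2nc3ccccc3nc2S(=O)(=O)c2ccc(C)cc2)cc(OC)c1` gives 8060 nM. Compound 3 thus sits among the two higher numbers of the three: compound 2 lies within the scatter of it, while compound 1 lies far lower. Compound 4 `COc1ccc(S(=O)(=O)c2nc3ccccc3nc2Nc2cc(OC)cc(OC)c2)cc1` differs from compound 3 by methoxy in place of methyl on an aromatic carbon. Of the measured steps, only a 120-fold higher number from compound 1 to compound 3 (2.06 log units; beyond the scatter) concerns the same aromatic carbon, and that step was large; a 1.6-fold lower number from compound 2 to compound 3 (0.19 log units; within the scatter) concerns the nitrogen on the other side of the shared core and stayed within the scatter. Among the compounds with values here, the record therefore shows that this aromatic carbon is one at which a single exchange has gone together with a big step in this assay, yet no measured pair shows a methoxy there, so the direction of the new step is open. For compound 4 the expected value is 6000 nM, with a range from 1000 nM to 40000 nM. The expected step of a 1.3-fold lower number from compound 3 to compound 4 (0.13 log units; within the scatter) is accordingly small, with wide uncertainty.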

Compound 4, half-maximal inhibitory concentration: 12700 nM
Estimate against measurement, compound 4: 2.1-fold (0.33 log units) below, and the stated range covers the measured number.
By their numbers in this assay, from the lowest: compound 1; then compounds 3, 2 and 4 (each within the scatter of the next).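

In this assay, the carbon para to a large group now has a second substituent, and a 1.6-fold higher number from compound 3 to compound 4 (0.20 log units; within the scatter) shows that methoxy and methyl in place of each other make no difference beyond the scatter. Methoxy in place of hydrogen gives a 180-fold higher number from compound 1 to compound 4 (2.26 log units; beyond the scatter), a large step in the same direction as a 120-fold higher number from compound 1 to compound 3 (2.06 log units; beyond the scatter), so among compounds 1, 3 and 4 both substituted compounds stand far from the unsubstituted compound 1. Nothing available explains this shared large step.

The compounds shown leave open whether fluorine, an amine or a carboxylic acid at this carbon would stay near compound 1 at 70 nM or join compounds 3 and 4. They also leave open whether the large step from hydrogen depends on the 3,5-dimethoxyphenyl on the nitrogen.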